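The compounds below may be only part of what the source reports. "The series", "measured", "known", "first", "only" and "open" are said of these compounds alone.

Of the compounds shown here, two have so far been measured in an assay on isolated protein for inhibition of Rho-associated protein kinase 1 (Homo sapiens), read by radiometric assay and 33P incorporation, with a stated time of 40 min, in the presence of a further agent that is not named here; on this read-out higher numbers stand for weaker inhibition and lower numbers for stronger inhibition. Compound 1 `COc1cccc(CN2CCc3cc(-c4ccc5[nH]ncc5c4)ccc3C2=O)c1` gives 2060 nM in this assay. Compound 2 `COc1cccc(Cn2cnc3sc(-c4ccc5[nH]ncc5c4)cc3c2=O)c1` gives 20 nM, the lowest of the two numbers, with compound 1 standing far above it by a gap well beyond the usual scatter.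

Compound 3 `COc1cccc(Cn2cnc3sc(-c4ccnc(F)c4)cc3c2=O)c1` is not yet measured. It differs from compound 2 in one place: 2-fluoropyridin-4-yl in place of 1H-indazol-5-yl on an aromatic carbon. Within the data shown here, no pair of measured compounds shows this change, so its effect is unknown here. A step toward weaker inhibition, clearly beyond the scatter, is expected, namely a 20-fold higher number from compound 2 to compound 3 (1.30 log units; beyond the scatter). Compound 3 is estimated to give 400 nM in this assay, within a range from 80 nM to 2500 nM.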

Compound 3, half-maximal inhibitory concentration: 1050 nM
Beside the measured number, compound 3's estimate is 2.6-fold (0.42 log units) below it, and the stated range covers the measured number.
By their numbers in this assay, from the lowest: compound 2; then compounds 3 and 1 (each within the scatter of the next).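

At the place next to the ring sulfur, the group matters greatly in this assay: 2-fluoropyridin-4-yl in place of 1H-indazol-5-yl gives a 53-fold higher number from compound 2 to compound 3 (1.72 log units; beyond the scatter) and clearly weakens inhibition. This position therefore does not treat these two aromatic groups alike, and the change removes the hydrogen-bond donor and one ring. Nothing measured here accounts for the size of this step. On these data alone, whether the loss follows the missing donor, the missing ring or the added fluorine stays open. A pyridin-4-yl carrying an amine in place of the fluorine would help separate these.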